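The source may report more compounds than this note shows. Statements on the series, on what has been measured and on what is new or still open speak of the compounds shown alone.

Working notes on the series, all read in a functional assay on HepG2 cells (Homo sapiens) for inhibition, read by MTT assay, with a stated time of 48 h; a lower number here means a stronger inhibitor, a higher number a weaker inhibitor. Compound 1 (`O=C(Nc1cccc(Cl)c1)Nc1ccc(-c2cc(=O)c3ccccc3o2)c(Cl)c1`) gives 9700 nM, compound 2 (`CCc1ccc2oc(-c3ccc(NC(=O)Nc4cccc(Cl)c4)cc3Cl)cc(=O)c2c1`) gives 30700 nM and compound 3 (`COc1ccc2oc(-c3ccc(NC(=O)Nc4cccc(Cl)c4)cc3Cl)cc(=O)c2c1`) gives 26300 nM. Adding a group to the core of compound 1 raises the number in both cases, by a modest amount: a 3.2-fold higher number from compound 1 to compound 2 (0.50 log units; beyond the scatter) with ethyl and a 2.7-fold higher number from compound 1 to compound 3 (0.43 log units; beyond the scatter) with methoxy. Compound 3 therefore stands clearly higher than compound 1 but level with compound 2, with a 1.2-fold lower number from compound 2 to compound 3 (0.07 log units; within the scatter).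

Compound 4 (`COc1ccc2oc(-c3ccc(NC(=O)Nc4ccc(Cl)c(Cl)c4)cc3Cl)cc(=O)c2c1`) keeps the core of compound 3 and turns 3-chlorophenyl into 3,4-dichlorophenyl: chloro in place of hydrogen on an aromatic carbon. Among the compounds with values here, no measured step touches this group, since 3-chlorophenyl is common to compounds 1, 2 and 3 and all three steps lie on the core. They bear on the question only loosely, as a guide to size: a single added group on compound 1 gave a 2.7-fold higher number from compound 1 to compound 3 (0.43 log units; beyond the scatter). The data give no direction for the new chloro, so no step beyond the scatter is expected. The expected step is a 1.3-fold lower number from compound 3 to compound 4 (0.12 log units; within the scatter). For compound 4 the estimate is 20000 nM, with an expected range of 8000 nM to 50000 nM.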

Compound 4, half-maximal inhibitory concentration: 9900 nM
Beside the measured number, compound 4's estimate is 2.0-fold (0.31 log units) above it, within the range that was stated.
By their numbers in this assay, from the lowest: compounds 1 and 4 (each within the scatter of the next); then compounds 3 and 2 (each within the scatter of the next).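

In this assay, the first change shown on the 3-chlorophenyl rather than on the core lowers the number (a 2.7-fold lower number from compound 3 to compound 4 (0.42 log units; beyond the scatter)). The position para to a large group and ortho to a chloro group therefore responds to chloro in place of hydrogen, with a modest step opposite in direction to the two steps made by adding a group to the core of compound 1, ethyl (a 3.2-fold higher number from compound 1 to compound 2 (0.50 log units; beyond the scatter)) and methoxy (a 2.7-fold higher number from compound 1 to compound 3 (0.43 log units; beyond the scatter)). Nothing available on these compounds accounts for the step.

The compounds shown leave open whether the same change gives a similar step on the core of compound 1 or of compound 2, since the only reading of it here is on the methoxy core of compound 3. They also leave open whether the response at this position is specific to chloro or would also appear with another group there, such as fluoro, methyl, trifluoromethyl, an amine or a carboxylic acid.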